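A few compounds are considered here, and "the series" means these few. Any claim that something is new, unique, unknown or untested is made for them only; others in the source may bear on it.

Compounds measured so far:
- compound 1, `CN1CCN(c2nc(-c3ccc(Cl)c(Cl)c3)nc3[nH]cnc23)CC1`: 24.1%
- compound 2, `Cn1cnc2c(N3CCCCC3)nc(-c3cccc(O)c3O)nc21`: 26%
- compound 3, `CN1CCN(c2nc(-c3cc(Cl)ccc3Cl)nc3[nH]cnc23)CC1`: 13%

These three were tested in an assay on cells for displacement of a labelled ligand from adenosine receptor A2b (Homo sapiens), read by scintillation counting and radioligand binding, with a stated time of 30 min, tested at 10 uM; a higher number here means more inhibition at the concentration tested (going by the name of the read-out), a lower number less inhibition. On the numbers shown, compound 2 and compound 1 give read-outs within the usual scatter of each other, so no order between them can be claimed. Within the data shown here, compound 3 lies lower than both; the one step that can be followed exactly, a number 11.1 percentage points lower from compound 1 to compound 3 (beyond the scatter), shows how much a shift of the two chlorines around the phenyl ring costs.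

The next compound, compound 4 `Cn1cnc2c(N3CCCCC3)nc(-c3cccc(O)c3)nc21`, is made from compound 2 by the change (hydrogen in place of hydroxy on an aromatic carbon). Among the measured compounds shown here, no measured step bears on this kind of change: the only step on record swaps chlorine positions and leaves nothing behind, whereas here one hydroxy group is lost. There is thus no measured basis for a large expected step in either direction, and the most cautious expectation is a small change, if any, beyond the scatter, with somewhat more room on the downward side since the value of compound 2 already sits near the other two.

Compound 4 is therefore expected to give 20%, within a range from 5% to 35%. That estimate corresponds to an expected step of a number 6 percentage points lower from compound 2 to compound 4 (within the scatter).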

Compound 4, a percentage reported as inhibition, at one concentration (the size of the read-out at that concentration, not a potency): 29.3%
Estimate against measurement, compound 4: 9.3 percentage points below, within the range that was stated.
By their numbers in this assay, from the lowest: compound 3; then compounds 1, 2 and 4 (each within the scatter of the next).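

In this assay the change from 2,3-dihydroxyphenyl to 3-hydroxyphenyl, with hydrogen in place of hydroxy on an aromatic carbon, gives a number 3.3 percentage points higher from compound 2 to compound 4 (within the scatter) and so shows no change that can be claimed. Among these compounds, this is the first look at this place on the ring, ortho to a hydroxy group and ortho to a large group, and it shows that the read-out holds up with the hydroxy group gone, so that group is not required for the level of inhibition seen at this single concentration. Nothing available explains why the read-out holds when this group is lost.

The compounds shown leave open what the remaining hydroxy group on the ring contributes, and whether a different group at the place now carrying hydrogen, such as a methoxy group or an amine, would move the read-out beyond the scatter. Also open, on these data alone, is how these two compounds compare in potency, as a percentage at one concentration gives the size of the read-out and not a potency, and only a full concentration series could separate them.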